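Trimethoxyphenyl Analogue of a Pyrazolopyrimidine Chalcone

The compounds below may be only part of what the source reports. "The series", "measured", "known", "first", "only" and "open" are said of these compounds alone.

Measured compounds:
compound 1, `COc1ccc(-c2cc(C(=O)/C=C/c3ccccc3)nc3cc(-c4ccccc4)nn23)cc1OC`, 18600 nM
compound 2, `COc1ccc(/C=C/C(=O)c2cc(-c3ccc(OC)c(OC)c3)n3nc(-c4ccccc4)cc3n2)cc1`, 19300 nM
compound 3, `COc1ccc(-c2cc(/C=C/C(=O)c3ccc(C)cc3)nc3cc(-c4ccccc4)nn23)cc1OC`, 17200 nM

The three measured compounds were tested in a functional assay on A549 cells (Homo sapiens) for antiproliferative activity, read by MTT assay, with a stated time of 24 h; on this read-out lower numbers stand for stronger inhibition and higher numbers for weaker inhibition. Compound 1 and compound 2 differ by methoxy in place of hydrogen on an aromatic carbon, and that change gave a 1.0-fold higher number from compound 1 to compound 2 (0.02 log units; within the scatter). The core of compound 3 differs from that of compound 1 by 2-((4-methylphenyl)carbonyl)ethenyl in place of (2-phenylethenyl)carbonyl on an aromatic carbon. Compound 4, `COc1cc(-c2cc(/C=C/C(=O)c3ccc(C)cc3)nc3cc(-c4ccccc4)nn23)cc(OC)c1OC`, has not yet been measured; it differs from compound 3 by methoxy in place of hydrogen on an aromatic carbon. This is the same kind of change as that from compound 1 to compound 2, though the surroundings differ: in compound 2 the entering methoxy sits para to a large group, whereas in compound 4 it sits ortho to a methoxy group, meta to a large group and meta to a methoxy group. Because the earlier methoxy step gave a 1.0-fold higher number from compound 1 to compound 2 (0.02 log units; within the scatter), compound 4 is expected to show a 1.0-fold higher number from compound 3 to compound 4 (0.01 log units; within the scatter). The estimate for compound 4 in this assay is 17500 nM, between 9000 nM and 35000 nM.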

Compound 4, half-maximal inhibitory concentration: 19400 nM
Beside the measured number, compound 4's estimate is 1.1-fold (0.04 log units) below it; the range from low to high includes it.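

In this assay, the methoxy that turns 3,4-dimethoxyphenyl into 3,4,5-trimethoxyphenyl gave a 1.1-fold higher number from compound 3 to compound 4 (0.05 log units; within the scatter). Set beside the earlier methoxy step, the change carried from one core to the other with no difference that can be told from the scatter: the same change on two cores in this assay, a 1.0-fold higher number (0.02 log units; within the scatter) from compound 1 to compound 2 and a 1.1-fold higher number (0.05 log units; within the scatter) from compound 3 to compound 4, 1.1-fold (0.04 log units) apart, within the scatter of two such steps. This shows only that methoxy in place of hydrogen stayed within the scatter on both of these cores; it does not show that the same would hold on other cores, nor that the step has any real size of its own.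

The compounds shown leave open whether an amine or a hydroxy group in place of this methoxy would give a step beyond the scatter. They also leave open what a longer alkoxy chain or a carboxylic acid at the same place would do.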